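Aryl swap on the pyrazole: compound 3 to compound 4

This account rests on a few compounds, and the source may have more. Where it says the series, first, only, none or still open, it means among the compounds named here.

Within the data shown here, compound 3 `CN1CCN(CCNCc2cn(-c3ccc(F)cc3F)nc2-c2cccc(Cl)c2)CC1` is the one member of the set with a numerical value in an ADME assay on Huh-7 cells (Homo sapiens) for cytotoxicity (a higher number here means that more compound is tolerated, a lower number that less compound is tolerated), where compound 3 gives 15000 nM. Compound 1 `Cc1ccccc1CNc1nn(-c2ccc(F)cc2F)cc1CNCCN1CCN(C)CC1` reaches only the assay limit in this assay, > 20000 nM. Compound 2 `CN1CCN(CCNCc2cn(-c3ccc(F)cc3F)nc2C2CCCCC2)CC1` likewise stops at the limit, > 20000 nM, as noted for (the limit of > 20000 nM in this assay, at which 2 of the 3 values shown sit). The step to compound 4 `CN1CCN(CCNCc2cn(-c3ccc(F)cc3F)nc2-c2ccc(C(F)(F)F)cc2)CC1` is 4-(trifluoromethyl)phenyl in place of 3-chlorophenyl on an aromatic carbon. The measured steps that end at compound 3, an at least 1.3-fold lower number from compound 1 to compound 3 (0.12 log units; that floor lies within the scatter) and an at least 1.3-fold lower number from compound 2 to compound 3 (0.12 log units; that floor lies within the scatter), are floors within the scatter, so no direction beyond the scatter is expected for one aryl group replacing another. Compound 4 is expected at 15000 nM, with a range of 7000 nM to 30000 nM; the estimated step is no change at the digits printed from compound 3 to compound 4 (within the scatter).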

Compound 4, half-maximal cytotoxic concentration: 20000 nM
For compound 4 the middle estimate is 1.3-fold (0.12 log units) below the measured one; low and high end bracket the measured number.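

In this assay, among these compounds, 4-(trifluoromethyl)phenyl in place of 3-chlorophenyl on this aromatic carbon is the first step at this position with a number at both ends, and it gives a 1.3-fold higher number from compound 3 to compound 4 (0.12 log units; within the scatter), which places these two aryl groups, of 7 and 10 heavy atoms, within the scatter of each other. The other two steps, a number no higher from compound 2 to compound 4 (the limit leaves the size open) and a number no higher from compound 1 to compound 4 (the limit leaves the size open), cannot be read: the limit of > 20000 nM in this assay, at which 2 of the 4 values shown sit.

As far as these compounds go, what a carboxylic acid or a morpholine on this aromatic carbon would give in this assay remains open.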